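The source may report more compounds than this note shows. Statements on the series, on what has been measured and on what is new or still open speak of the compounds shown alone.

In a functional assay on HCT-116 cells (Homo sapiens) for cytotoxicity, read by MTT assay, with a stated time of 72 h (on this read-out lower numbers stand for stronger inhibition and higher numbers for weaker inhibition), compound 1 (`CN(C)CCCCCn1c2c(c3ccccc31)C(=O)c1c[n+]([O-])c3ccccc3c1C2=O`) gives 470 nM and compound 2 (`O=C1c2c[n+]([O-])c3ccccc3c2C(=O)c2c1c1ccccc1n2CCCCn1ccnc1`) gives 240 nM on the same core. Compound 3 (`O=C1c2c[n+]([O-])c3ccccc3c2C(=O)c2c1c1ccccc1n2Cc1cn([C@@H]2C[C@H](O)[C@@H](CO)O2)nn1`) gives 50 nM as the lowest of the three, clearly apart from both others. Compound 4 (`CC1(C)OCC(Cn2cc(Cn3c4c(c5ccccc53)C(=O)c3c[n+]([O-])c5ccccc5c3C4=O)nn2)O1`) has no number yet. It differs from compound 3 by (2,2-dimethyl-1,3-dioxolan-4-yl)methyl in place of 4-hydroxy-5-(hydroxymethyl)oxolan-2-yl on an aromatic nitrogen. For the measured compounds named here, the one measured single-place step is a 2.0-fold lower number from compound 1 to compound 2 (0.29 log units; within the scatter) and concerns a different group on a saturated chain, so it is only a loose guide. Going by the values given here, no measured compound carries the entering group. The change removes the group found only in compound 3, which at 50 nM stands lowest, so a moderate move to a higher number in this assay is expected, with wide uncertainty. The estimated change is a 3.0-fold higher number from compound 3 to compound 4 (0.48 log units; beyond the scatter) and may prove smaller or larger. Compound 4 is estimated at 150 nM with an expected range of 45 nM to 500 nM for now.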

Compound 4, half-maximal inhibitory concentration: 70 nM
The estimate for compound 4 lay 2.1-fold (0.33 log units) above the measured number; the range from low to high includes it.
By their numbers in this assay, from the lowest: compounds 3 and 4 (each within the scatter of the next); then compounds 2 and 1 (each within the scatter of the next).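

In this assay, the exchange on an aromatic nitrogen of the five-membered aromatic ring with 3 nitrogen is a 1.4-fold higher number from compound 3 to compound 4 (0.15 log units; within the scatter). This position therefore accepts two quite different groups without a readable change: 4-hydroxy-5-(hydroxymethyl)oxolan-2-yl, with 2 hydrogen-bond donors and 3 defined stereocentres, and (2,2-dimethyl-1,3-dioxolan-4-yl)methyl, with 0 hydrogen-bond donors, so neither those donors nor those stereocentres are needed for a value at this level on this read-out. Nothing available accounts for the two groups reading alike.

The compounds shown leave open whether a 2,3-dihydroxypropyl group, a plain hexyl chain, a primary amine or a carboxylic acid on this aromatic nitrogen would keep the number. They also leave open whether the five-membered aromatic ring with 3 nitrogen could give way to an amide link.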